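Swapping the carbonyl substituent on compound 3

The compounds below may be only part of what the source reports. "The series", "measured", "known", "first", "only" and "open" are said of these compounds alone.

In a physicochemical assay for solubility, read by HPLC, in phosphate buffer, measured as kinetic solubility, at pH 7.4 (on this read-out lower numbers stand for lower solubility and higher numbers for higher solubility), compound 1 `CC(C)(C)C(=O)c1cc(-c2ccc(S(N)(=O)=O)cc2)n(-c2ccc(Cl)cc2)n1` gives 6600 nM and compound 2 `NS(=O)(=O)c1ccc(-c2cc(C(=O)CC3CCC3)nn2-c2ccc(Cl)cc2)cc1` gives 4300 nM while compound 3 `NS(=O)(=O)c1ccc(-c2cc(C(=O)CC3CCCC3)nn2-c2ccc(Cl)cc2)cc1` stands at 2600 nM in this set. One of its gaps is beyond the scatter (a 2.5-fold lower number from compound 1 to compound 3 (0.40 log units; beyond the scatter)) and the other is not (a 1.7-fold lower number from compound 2 to compound 3 (0.22 log units; within the scatter)). Compound 4 `CN(C(=O)c1cc(-c2ccc(S(N)(=O)=O)cc2)n(-c2ccc(Cl)cc2)n1)C1CC(F)(F)C1` carries the change (3,3-difluorocyclobutyl)(methyl)amino in place of cyclopentylmethyl on a carbonyl carbon (in words, (3,3-difluorocyclobutyl)(methyl)amino in place of cyclopentylmethyl on a carbonyl carbon). The measured steps, together with the third (a 1.5-fold lower number from compound 1 to compound 2 (0.19 log units; within the scatter)), are modest at most. None of them brings in an amino group, so they guide the expectation only loosely. No step beyond the scatter is expected in this assay here (expected: a 1.2-fold higher number from compound 3 to compound 4 (0.09 log units; within the scatter)). Compound 4 is estimated at 3200 nM (expected range 1100 nM to 9000 nM).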

Compound 4, solubility: 30900 nM
Beside the measured number, compound 4's estimate is 9.7-fold (0.98 log units) below it; measured number above the stated range.
By their numbers in this assay, from the lowest: compounds 3, 2 and 1 (each within the scatter of the next, the first and the last beyond it); then compound 4.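

In this assay, among these compounds, the carbonyl carbon position shows a far wider range than the earlier compounds did: (3,3-difluorocyclobutyl)(methyl)amino stands higher than cyclopentylmethyl (a 12-fold higher number from compound 3 to compound 4 (1.07 log units; beyond the scatter)), cyclobutylmethyl (a 7.2-fold higher number from compound 2 to compound 4 (0.86 log units; beyond the scatter)) and tert-butyl (a 4.7-fold higher number from compound 1 to compound 4 (0.67 log units; beyond the scatter)). The widest earlier step was only modest (a 2.5-fold lower number from compound 1 to compound 3 (0.40 log units; beyond the scatter)), and all three of those groups join the carbonyl through carbon. No supporting measurement explains the rise. Open, going by these compounds, is whether the step follows the amino link or the two fluorines; cyclobutyl(methyl)amino and (3,3-difluorocyclobutyl)methyl would separate them.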